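The compounds below may be only part of what the source reports. "The series", "measured", "known", "first", "only" and "open" are said of these compounds alone.

In a functional assay on MCF7 cells (Homo sapiens) for antiproliferative activity, read by MTT assay, with a stated time of 48 h (a lower number here means a stronger inhibitor, a higher number a weaker inhibitor), two compounds have been measured so far. Compound 1 `CNCC(=O)Nc1cc(OC)ccc1C(=O)c1cc(OC)c(OC)c(OC)c1` gives 550 nM, and compound 2 `C=C(c1ccc2c(c1)C=CC(C)(C)O2)c1ccc(OC)cc1NC(=O)CN` gives 420 nM. These two values lie within the usual scatter of repeated measurements, so the numbers do not separate compound 1 from compound 2.

Compound 3 `COc1ccc(C(=O)c2cc(OC)c(OC)c(OC)c2)c(NC(=O)CN)c1` has not yet been measured. It differs from compound 1 in one place: hydrogen in place of methyl on an amine nitrogen, which turns methylamino into amino. Among the compounds with values here, no measured pair of compounds shows this change on its own, so its size can only be judged indirectly. The (aminomethyl)carbonyl group of compound 3 also stands in compound 2, which gives 420 nM on a different core, so a small step is expected, with no size beyond the scatter and no firm direction. The step expected is a 1.4-fold lower number from compound 1 to compound 3 (0.14 log units; within the scatter). For compound 3 the estimated value is 400 nM, with an expected range of 130 nM to 1300 nM.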

Compound 3, half-maximal inhibitory concentration: 270 nM
Compound 3: the middle estimate sits 1.5-fold (0.17 log units) above what was measured; the measured number falls inside the stated range.
By their numbers in this assay, from the lowest: compounds 3, 2 and 1 (each within the scatter of the next, the first and the last beyond it).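

In this assay, taking the methyl off the amine nitrogen, which turns methylamino into amino, gives a 2.0-fold lower number from compound 1 to compound 3 (0.31 log units; beyond the scatter). Within the data shown here, this is the only comparison here between compounds that differ in one place, and it shows that the amine nitrogen is not indifferent to what it carries: a single carbon is enough to move the number just past the usual scatter, and the form with hydrogen is the stronger of this pair. The step remains modest, and no measurement at hand accounts for it.

Going by these compounds, whether an ethyl group, a longer chain or a second methyl on this nitrogen, the last giving dimethylamino, would move the number further remains open. So does whether methylamino in place of amino on the core of compound 2 would give a step of similar size and direction, which would show whether this effect holds beyond the core shared by compound 1 and compound 3.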